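From an aryl group to an anilide on the carbonyl carbon

The compounds below may be only part of what the source reports. "The series", "measured", "known", "first", "only" and "open" are said of these compounds alone.

Compound 2 `COc1cc(-c2nnc(SCC(=O)c3ccccc3F)n2N)cc(OC)c1OC` and compound 1 `COc1cc(-c2nnc(SCC(=O)c3ccc(C)cc3)n2N)cc(OC)c1OC` share one core and differ only in the group attached to the carbonyl carbon. Among the compounds with values here, in a functional assay on HepG2 cells (Homo sapiens) for antiproliferative activity, read by MTT assay, with a stated time of 48 h (a lower number here means a stronger inhibitor, a higher number a weaker inhibitor), compound 2 gives 22600 nM, the only definite number among the two values shown. For compound 1 the assay reports only a limit, > 100000 nM. Within the data shown here, the single step that can be read, an at least 4.4-fold lower number from compound 1 to compound 2 (0.64 log units; beyond the scatter), rests on that limit of > 100000 nM in this assay, at which 1 of the 2 values shown sits, and shows that the group on the carbonyl carbon does move the number.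

Compound 3 `COc1cccc(NC(=O)CSc2nnc(-c3cc(OC)c(OC)c(OC)c3)n2N)c1` has not yet been measured. It differs from compound 2 by (3-methoxyphenyl)amino in place of 2-fluorophenyl on a carbonyl carbon. Among the measured compounds shown here, no measured step exchanges a carbon-linked ring for a nitrogen-linked one at this position, so the measured step bears on it only by showing that this position matters. One therefore expects the step of a 1.5-fold higher number from compound 2 to compound 3 (0.19 log units; within the scatter) to be smaller than that measured step and uncertain in direction, with a real chance that only a limit is reported. Compound 3 is estimated at 35000 nM, with a range from 8000 nM to 150000 nM.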

Compound 3, half-maximal inhibitory concentration: > 100000 nM
Compound 3: a limit, no number; the forecaster's own chance of this, stated with the estimate: 25%; middle value at least 2.8-fold (0.45 log units) from the limit.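

Exchanging 2-fluorophenyl for (3-methoxyphenyl)amino on a carbonyl carbon gives an at least 4.4-fold higher number from compound 2 to compound 3 (0.64 log units; beyond the scatter) in this assay, so the earlier finding that this position moves the number now extends to a change of the linking atom, and this anilide does not keep the measurable activity of the 2-fluorophenyl ketone. In the same assay compound 3 gives > 100000 nM, which is a limit and not a number. Compound 2 therefore stands as the only one of the three with a definite value, the step between the two compounds that carry limits cannot be read, and every comparison here leans on one ceiling: the limit of > 100000 nM in this assay, at which 2 of the 3 values shown sit.

The step changes the linking nitrogen and the ring substituent together, so the compounds shown do not tell which of the two goes with the higher number. A 2-fluorophenylamino group on the carbonyl carbon would separate these two changes, and a benzylamino group or a simple alkyl amine there would show whether any nitrogen-linked group can give a definite value.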